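A few compounds are considered here, and "the series" means these few. Any claim that something is new, unique, unknown or untested is made for them only; others in the source may bear on it.

Compound 1 `COc1cccc(CCC(=O)Nc2nc3ccccc3c(=O)s2)c1` carries the shared core linked through an amide to a chain ending in a 3-methoxyphenyl group. In an assay on CHO cells for displacement of a labelled ligand from adenosine receptor A2b (Homo sapiens), read by scintillation counting, with a stated time of 75 min (a lower number here means a stronger inhibitor, a higher number a weaker inhibitor), compound 1 gives 225 nM. Compound 2 `O=C(COc1cccc(Cl)c1)Nc1nc2ccccc2c(=O)s1` is reported in this assay only as a limit, > 1000 nM. Among the two values shown, compound 1 therefore holds the only true number, the other being (the limit of > 1000 nM in this assay, at which 1 of the 2 values shown sits). Compound 3 `O=C(CCCc1cccc(Cl)c1)Nc1nc2ccccc2c(=O)s1` differs from compound 1 by 3-chlorobenzyl in place of 3-methoxyphenyl on a saturated chain carbon, two bonds along the chain from a carbonyl carbon. For the measured compounds named here, no measured pair shows a change of this kind, so the step from compound 1 to compound 3 is expected to be a 1.6-fold higher number from compound 1 to compound 3 (0.19 log units; within the scatter), a modest loss at most. Compound 3 is estimated at 350 nM, most likely between 120 nM and 1200 nM.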

Compound 3, inhibition constant: >= 1000 nM
Compound 3 was reported as a limit (the forecaster's own chance of this, stated with the estimate: 25%); middle value at least 2.8-fold (0.45 log units) away from the limit.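

For the compounds shown here, the first measured step at this position is an at least 4.4-fold higher number from compound 1 to compound 3 (0.64 log units; beyond the scatter) in this assay, so this swap on the chain is not neutral, even though both groups have 8 heavy atoms. The group that enters carries no hydrogen-bond acceptor, while the group that leaves carries 1, but the data do not show whether this difference matters. Compound 3 is reported only as a limit: the limit of >= 1000 nM in this assay, at which 1 of the 3 values shown sits.

As far as these compounds go, the full size of the step therefore stays open. Also open, from the compounds shown here alone, is how an amine, a carboxylic acid or a longer chain would fare at this position.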